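Compound 3 and a Dichlorophenyl Replacement

A few compounds are considered here, and "the series" means these few. Any claim that something is new, unique, unknown or untested is made for them only; others in the source may bear on it.

Compound 3 `O=C1COc2ccc(-c3[nH]c(-c4c[nH]c5ncccc45)nc3-c3ccccc3)cc2N1` was tested in a functional assay on DLD-1 cells (Homo sapiens) for cytotoxicity, read by colorimetric assay and MTT assay, with a stated time of 3 days, tested at 20 uM (a higher number here means a weaker effect of the compound at the concentration tested, a lower number a stronger effect), where compound 3 gives 53.5%. Of the three measured compounds this is the second highest number: compound 2 `Cc1ccccc1-n1cc(-c2ccccc2)c(-c2ccc3c(c2)NC(=O)CO3)n1` gives 62.9%, a gap within the usual scatter, while compound 1 `COc1ccc(-n2cc(-c3ccccc3)c(-c3ccc4c(c3)NC(=O)CO4)n2)cc1` gives 35.6%, a gap beyond it. Compound 4 `O=C1COc2ccc(-c3[nH]c(-c4ccc(Cl)cc4Cl)nc3-c3ccccc3)cc2N1` is not yet measured and differs from compound 3 in one place: a group of 8 heavy atoms (6 carbon, 2 chlorine; one six-membered aromatic ring of carbon only) in place of a group of 9 heavy atoms (7 carbon, 2 nitrogen; one five-membered aromatic ring with 1 hetero atom, one six-membered aromatic ring with 1 hetero atom), on an aromatic carbon. Among the compounds with values here, the only measured step, a number 27.3 percentage points higher from compound 1 to compound 2 (beyond the scatter), alters a group on an aromatic nitrogen in a different core, so it does not bear directly on this change. No direction can therefore be expected with confidence. Compound 4 is estimated at 50%, with a range of 25% to 80%. That estimate means an expected step of a number 3.5 percentage points lower from compound 3 to compound 4 (within the scatter), within the scatter.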

Compound 4, a percentage reported as activity, at one concentration (the size of the read-out at that concentration, not a potency): 61.9%
Beside the measured number, compound 4's estimate is 11.9 percentage points below it; the range from low to high includes it.
By their numbers in this assay, from the lowest: compound 1; then compounds 3, 4 and 2 (each within the scatter of the next).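

Swapping the two-ring group on the aromatic carbon between two ring nitrogen atoms for 2,4-dichlorophenyl gives a number 8.4 percentage points higher from compound 3 to compound 4 (within the scatter) in this assay. At this position, then, a carbon-only ring with 0 hydrogen-bond donors and 0 hydrogen-bond acceptors gives a result that cannot be told apart from that of the group it replaces, which has 1 of each. No measurement on hand explains this result.

The compounds shown leave open what an amine or a carboxylic acid at this position would give in this assay. They also leave open how a phenyl group without its two chlorine atoms would compare with compound 4.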